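This account rests on a few compounds, and the source may have more. Where it says the series, first, only, none or still open, it means among the compounds named here.

Compound 1 `Cc1cccc(NC(=O)c2ccc3cccc(O)c3n2)c1`: 2.5; compound 2 `O=C(Nc1cccc(Br)c1)c1ccc2cccc(O)c2n1`: 2.5.

In a physicochemical assay for lipophilicity, read by HPLC (on this read-out higher numbers stand for higher lipophilicity and lower numbers for lower lipophilicity), compound 2 stands level with compound 1, the step of no change at the digits printed from compound 1 to compound 2 (within the scatter) lying within the scatter. Compound 3 `O=C(Nc1cccc([N+](=O)[O-])c1)c1ccc2cccc(O)c2n1` differs from compound 2 in one place: nitro in place of bromo on an aromatic carbon. No measured step exchanges bromo for nitro; the single step shown, from compound 1 to compound 2, left this assay unchanged, so it offers no direct guide. The change to compound 3 replaces one heavy atom with three and adds two hydrogen-bond acceptors, and a downward step in this assay is expected, a number 0.80 log units lower from compound 2 to compound 3 (beyond the scatter). Compound 3 is estimated at 1.7, within a range from 1.2 to 2.2.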

Compound 3, partition coefficient: 2.5
Compound 3: middle estimate off by 0.80 log units, on the low side; measured number outside the range, above it.
By their numbers in this assay, from the lowest: compounds 1, 2 and 3 (each within the scatter of the next).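

Nitro in place of bromo gives no change at the digits printed from compound 2 to compound 3 (within the scatter) in this assay and nitro in place of methyl gives no change at the digits printed from compound 1 to compound 3 (within the scatter) on the same aromatic carbon. This position has now carried methyl, bromo and nitro with the numbers staying level, even though nitro brings more heavy atoms and hydrogen-bond acceptors. No measured evidence accounts for this.

From the compounds shown here alone, whether an amine or a carboxylic acid on this carbon would also keep the number level remains open. So does whether nitro would do the same on another carbon of this ring.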